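Demethylation of an aryl methoxy in a pyrazole series

This account rests on a few compounds, and the source may have more. Where it says the series, first, only, none or still open, it means among the compounds named here.

Compound 1 `COc1cc(C)cc(-c2nn(CC#N)cc2-c2ccc(-c3cccc(C(C)=O)c3)nc2)c1`: 93%
Compound 2 `Cc1cc(O)cc(-c2nn(CC#N)cc2-c2ccnc(-c3ccc(Oc4ccccc4)cc3)c2)c1`: 104%
Compound 3 `COc1cc(C)cc(-c2nn(CC#N)cc2-c2ccnc(-c3ccc(N(C)C)cc3)c2)c1`: 105%

Of the compounds shown here, three of a shared core have been tested in a functional assay on HT-29 cells (Homo sapiens) for cytotoxicity, read by sulforhodamine B assay, with a stated time of 48 h, tested at 0.01 uM; a higher number here means a weaker effect of the compound at the concentration tested, a lower number a stronger effect. Compound 3 gives 105%, the highest of the three numbers. Its nearest neighbour is compound 2, which gives 104%, a number within the scatter of that of compound 3; the furthest is compound 1, which gives 93%, a number beyond the scatter below it. Compound 1 and compound 2 differ from compound 3 in more than one place, so nothing can be read from them beyond their two values.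

The next compound is compound 4 `Cc1cc(O)cc(-c2nn(CC#N)cc2-c2ccnc(-c3ccc(N(C)C)cc3)c2)c1`. It differs from compound 3 in one place: hydrogen in place of methyl on an oxygen on an aromatic ring.

Among the compounds with values here, no step between measured compounds matches this change. In this assay all three numbers lie close to one another, and compound 2, which also carries the hydroxy, gives 104%. For that reason the expected step of a number 2 percentage points lower from compound 3 to compound 4 (within the scatter) is none beyond the scatter. Compound 4 is therefore estimated at 103%, with a range from 90% to 115%.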

Compound 4, a percentage reported as activity, at one concentration (the size of the read-out at that concentration, not a potency): 96%
For compound 4 the middle estimate is 7 percentage points above the measured one; low and high end bracket the measured number.
By their numbers in this assay, from the lowest: compounds 1, 4, 2 and 3 (each within the scatter of the next, the first and the last beyond it).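

In this assay the change from methoxy to hydroxy on an oxygen on an aromatic ring now has a step of its own: it gives a number 9 percentage points lower from compound 3 to compound 4 (within the scatter) and so cannot be told apart from the usual scatter. With the hydroxy held in place, dimethylamino in place of phenoxy gives a number 8 percentage points lower from compound 2 to compound 4 (within the scatter) and likewise stays inside the scatter, so neither change shows an effect on this read-out at this one concentration. No measurement is at hand that bears on these results.

As far as these compounds go, whether an amine or an ethoxy group in place of the hydroxy would give a step beyond the scatter stays open. From the compounds shown here alone, it also stays open whether the step from methoxy to hydroxy would keep its size at a higher concentration.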